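A Methyl Added to the Outer Phenyl Ring

The source may report more compounds than this note shows. Statements on the series, on what has been measured and on what is new or still open speak of the compounds shown alone.

Of the compounds shown here, two with a shared core have been tested for how strongly they slow the growth of human lung cancer cells, read as a functional assay on A549 cells (Homo sapiens) for antiproliferative activity, read by MTT assay, with a stated time of 24 h; on this read-out higher numbers stand for weaker inhibition and lower numbers for stronger inhibition. Compound 1 `Cc1ccccc1-n1cc(-c2ccccc2NS(=O)(=O)c2c[nH]c(=O)[nH]c2=O)nn1` gives 3210 nM. Compound 2 `O=c1[nH]cc(S(=O)(=O)Nc2cccc(-c3cn(-c4ccccc4)nn3)c2)c(=O)[nH]1` gives 12700 nM, the higher of the two numbers, and its gap to compound 1 lies beyond the usual scatter of repeated runs; because the two differ in more than one place, nothing further can be drawn from that pair. Compound 3 `Cc1ccc(-n2cc(-c3cccc(NS(=O)(=O)c4c[nH]c(=O)[nH]c4=O)c3)nn2)cc1` differs from compound 2 by a single change, (methyl in place of hydrogen on an aromatic carbon), that is, methyl in place of hydrogen on an aromatic carbon. Within the data shown here, no measured pair shows what such a change does here, so the expectation rests on its small size: the estimated step is a 1.3-fold lower number from compound 2 to compound 3 (0.10 log units; within the scatter), not expected to reach beyond the scatter. Compound 3 is therefore expected to give about 10000 nM, within a likely range from 4000 nM to 25000 nM.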

Compound 3, half-maximal inhibitory concentration: 3630 nM
For compound 3 the middle estimate is 2.8-fold (0.44 log units) above the measured one, outside the stated range (below it).
By their numbers in this assay, from the lowest: compounds 1 and 3 (each within the scatter of the next); then compound 2.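

Going from phenyl to 4-methylphenyl matters more than the size of the change suggests: in this assay the step is a 3.5-fold lower number from compound 2 to compound 3 (0.54 log units; beyond the scatter) and it comes from a single added methyl. This shows that the aromatic carbon para to a large group on the outer ring is not a silent position, since one added carbon moves the number beyond the usual scatter of repeated runs. No measurement at hand accounts for a step of this size from so small a change.

The compounds shown leave open whether this step belongs to methyl in particular or would also follow from a larger or different group here, such as an ethyl chain, a methoxy group, an amine or a carboxylic acid. They also leave open whether a methyl placed elsewhere on the same ring would give a similar step.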